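A few compounds are considered here, and "the series" means these few. Any claim that something is new, unique, unknown or untested is made for them only; others in the source may bear on it.

Working notes on the series.

Of the compounds shown here, two have numbers so far. Compound 1 `Cc1ccc(Nc2nc(SCc3cn(CC(=O)NC(=O)Nc4ccccn4)nn3)nc(-c3ccc(Br)cc3)c2C#N)cc1` gives 7920 nM in a functional assay on ECa-109 cells (Homo sapiens) for inhibition, read by MTT assay, with a stated time of 72 h; a lower number here means a stronger inhibitor, a higher number a weaker inhibitor. Among the measured compounds shown here, compound 2 `N#Cc1c(Nc2cccc(C(F)(F)F)c2)nc(SCc2cn(CC(=O)NC(=O)Nc3ccccn3)nn2)nc1-c1ccc(Br)cc1` gives 2960 nM in this assay, the lowest of the two numbers; the only step measured is a 2.7-fold lower number from compound 1 to compound 2 (0.43 log units; beyond the scatter).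

Compound 3 `CC(C)c1ccc(Nc2nc(SCc3cn(CC(=O)NC(=O)Nc4ccccn4)nn3)nc(-c3ccc(Br)cc3)c2C#N)cc1` has not been measured in this assay. It differs from compound 2 by 4-isopropylphenyl in place of 3-(trifluoromethyl)phenyl on a nitrogen on an aromatic ring. For the measured compounds named here, the one measured step bears on this change only indirectly: compound 1 and compound 3 both carry an alkyl-substituted phenyl on that nitrogen, and the step from compound 1 to compound 2 shows what leaving such a group for 3-(trifluoromethyl)phenyl did. Reversing that kind of change is expected to move the number back toward the value of compound 1, with the isopropyl group possibly holding it slightly short of that. The expected step in this assay is therefore a 2.0-fold higher number from compound 2 to compound 3 (0.31 log units; beyond the scatter), a rise beyond the scatter. Compound 3 is estimated at 6000 nM in this assay, with a range from 2500 nM to 14000 nM.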

Compound 3, half-maximal inhibitory concentration: > 64000 nM
Compound 3 gave a limit, no number (the forecaster's own chance of this, stated with the estimate: 3%); at least 10-fold (1.02 log units) between middle value and limit.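

Compound 3 gives only a limit in this assay, not a number: the limit of > 64000 nM in this assay, at which 1 of the 3 values shown sits.

With 4-isopropylphenyl in place of 3-(trifluoromethyl)phenyl on the nitrogen, the result is an at least 21-fold higher number from compound 2 to compound 3 (1.33 log units; beyond the scatter), so the substituent on this phenyl can matter far more than a 2.7-fold lower number from compound 1 to compound 2 (0.43 log units; beyond the scatter) alone suggested. Isopropyl in place of methyl on an aromatic carbon gives an at least 8.0-fold higher number from compound 1 to compound 3 (0.90 log units; beyond the scatter), which shows that a change confined to the alkyl group is enough to carry the series out of the measurable range, and that the two alkyl-substituted compounds cannot be treated as alike at this position.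

The compounds shown leave open how far beyond its limit compound 3 lies, and whether the difference between compound 2 and compound 3 follows from the identity of the substituent or from where it sits on the phenyl, since the two differ in both. They also leave open how an unsubstituted phenyl, an ethyl group in place of the methyl or isopropyl, or a phenyl carrying an amine or a carboxylic acid would read on this nitrogen.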